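The compounds below may be only part of what the source reports. "The series", "measured", "known", "first", "only" and "open" are said of these compounds alone.

Of the compounds shown here, two built on the same core have so far been tested in a functional assay on K562 cells (Homo sapiens) for cytotoxicity, read by MTT assay, with a stated time of 48 h; a higher number here means a weaker inhibitor, a lower number a stronger inhibitor. In this test, compound 1 `CCOC(=O)[C@]1(C(=O)Nc2ccccc2)C[C@H]1c1cc(OC)c(OC)c(OC)c1` gives > 100000 nM, which is a limit of the assay and not a number. Compound 2 `CCOC(=O)[C@@]1(C(=O)NCc2ccc(C)cc2)C[C@H]1c1cc(OC)c(OC)c(OC)c1` gives > 100000 nM, again only a limit. Compound 2 therefore stands with its neighbour at the limit of > 100000 nM in this assay, at which 2 of the 2 values shown sit, and neither compound has yet given a true half-maximal inhibitory concentration.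

Compound 3 `CCOC(=O)[C@]1(C(=O)NCc2ccc(C)cc2)C[C@H]1c1cc(OC)c(OC)c(OC)c1` is a very close relative of compound 2: the two compounds have the same atoms and bonds and differ only in configuration as drawn: 1 of 2 stereo elements differ; a stereocentre at a saturated ring carbon is drawn S in compound 2 and R in compound 3. The two compounds have the same atoms and bonds, and a stereocentre at a saturated ring carbon is drawn S in compound 2 and R in compound 3.

The step expected a number no higher from compound 2 to compound 3 (the limit leaves the size open) is none beyond the usual scatter, with neither direction favoured. This expectation rests on compound 2, whose > 100000 nM is a limit. Compound 3 is estimated at 100000 nM, with an expected range from 40000 nM to 200000 nM, and the assay may well report only a limit again.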

Compound 3, half-maximal inhibitory concentration: > 100000 nM
Compound 3: only a limit was reported (the forecaster's own chance of this, stated with the estimate: 80%); the middle value sits exactly at the limit.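

Compound 3 also gives > 100000 nM in this assay, which is a limit of the assay and not a number. The steps from compound 1 and compound 2 to compound 3 cannot be read because all three compounds sit at the same limit: the limit of > 100000 nM in this assay, at which 3 of the 3 values shown sit.

The compounds shown leave open what true half-maximal inhibitory concentration any of them has, and whether the drawn configuration matters at all in this assay.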